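The source may hold more compounds than are shown below. What is called first, only, known or untested is meant among the compounds shown, and "the series" means these compounds.

In an ADME assay on RAW264.7 cells (Mus musculus) for cytotoxicity, read by MTT assay, with a stated time of 24 h (a lower number here means that less compound is tolerated, a higher number that more compound is tolerated), compound 1 `O=C1CSC(N2N=C(c3ccc(Cl)c(Cl)c3)CC2c2ccc(Cl)cc2)=N1` gives 187000 nM and compound 2 `Cc1ccc(C2=NN(C3=NC(=O)CS3)C(c3ccccc3Cl)C2)cc1C` gives 227000 nM and these two values lie within the scatter of each other. Compound 3 `Cc1ccc(C2=NN(C3=NC(=O)CS3)C(c3ccccc3)C2)cc1C` at > 450000 nM is reported only as a limit.

Compound 4 `O=C1CSC(N2N=C(c3ccc(Cl)c(Cl)c3)CC2c2ccc(F)cc2)=N1` has not yet been measured. Compared with compound 1, it carries fluoro in place of chloro on an aromatic carbon para to a large group, the change of 4-chlorophenyl to 4-fluorophenyl.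

The nearest measured exchange, a different one with hydrogen in place of chloro on an aromatic carbon, gives an at least 1.9-fold higher number from compound 2 to compound 3 (0.29 log units; that floor lies within the scatter) and compound 4 still keeps a halogen on its aromatic carbon, so only a small rise or none beyond the scatter is expected. The estimated change is a 1.3-fold higher number from compound 1 to compound 4 (0.13 log units; within the scatter) and it stays within the scatter. For compound 4 the expected value is 250000 nM with an estimated range from 130000 nM to 450000 nM as the likely span.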

Compound 4, half-maximal cytotoxic concentration: 139000 nM
Compound 4: middle estimate off by 1.8-fold (0.25 log units), on the high side; low and high end bracket the measured number.
By their numbers in this assay, from the lowest: compounds 4, 1 and 2 (each within the scatter of the next). At a limit, above all of these: compound 3.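

In this assay the change of 4-chlorophenyl to 4-fluorophenyl gives a 1.3-fold lower number from compound 1 to compound 4 (0.13 log units; within the scatter) and so, at this place para to a large group, the exchange of one halogen for the other cannot be told from the scatter. This is the first step shown between two plain numbers, and the first on this aromatic ring of the core of compound 1. Compound 3 stands only as a limit, so the earlier step is known only as a floor: the limit of > 450000 nM in this assay, at which 1 of the 4 values shown sits.

The compounds shown leave open how hydrogen, a methoxy group, an amine or a carboxylic acid in place of the halogen at this place would read in this assay. They also leave open whether the exchange would read the same way on other members of this series.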